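Benzylamine aryl substituent series: chloro to cyano step

The source may hold more compounds than are shown below. What is called first, only, known or untested is meant among the compounds shown, and "the series" means these compounds.

Measured so far:
- Compound 1 `C=C1CC[C@@H]2[C@](C)(CNCc3ccc(OC)cc3)[C@H](O)CC[C@@]2(C)[C@@H]1/C=C/C1=CCOC1=O`: in a functional assay on BMMC cells (Mus musculus, strain C57BL/6) for inhibition, with stated times of 5 days and 48 h (on this read-out lower numbers stand for stronger inhibition and higher numbers for weaker inhibition), compound 1 gives 750 nM
- Compound 2 `C=C1CC[C@@H]2[C@](C)(CNCc3ccc(OC)c(OC)c3)[C@H](O)CC[C@@]2(C)[C@@H]1/C=C/C1=CCOC1=O`: compound 2 gives 3740 nM
- Compound 3 `C=C1CC[C@@H]2[C@](C)(CNCc3ccc(Cl)cc3)[C@H](O)CC[C@@]2(C)[C@@H]1/C=C/C1=CCOC1=O`: compound 3 gives 420 nM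

Compound 3 gives the smallest of the three numbers, but against compound 1 the step of a 1.8-fold lower number from compound 1 to compound 3 (0.25 log units; within the scatter) lies within the scatter, so those two cannot be ordered; only against compound 2 is compound 3 clearly separated, by an 8.9-fold lower number from compound 2 to compound 3 (0.95 log units; beyond the scatter). The added methoxy in compound 2 costs a 5.0-fold higher number from compound 1 to compound 2 (0.70 log units; beyond the scatter).

Compound 4 `C=C1CC[C@@H]2[C@](C)(CNCc3ccc(C#N)cc3)[C@H](O)CC[C@@]2(C)[C@@H]1/C=C/C1=CCOC1=O` differs from compound 3 by cyano in place of chloro on an aromatic carbon. Going by the values given here, the step that bears on it is the one exchange of a group on the same aromatic carbon, methoxy to chloro, which gave a 1.8-fold lower number from compound 1 to compound 3 (0.25 log units; within the scatter) and stayed within the scatter; the step to compound 2 concerns a second substituent and is less informative. A further swap on that carbon is therefore expected to move this assay little, if at all, beyond the scatter, and a number near that of compound 3 is expected for compound 4.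

The expected step is a 1.4-fold higher number from compound 3 to compound 4 (0.15 log units; within the scatter). Compound 4 is estimated at 600 nM (range 250 nM to 1500 nM).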

Compound 4, half-maximal inhibitory concentration: 1130 nM
For compound 4 the middle estimate is 1.9-fold (0.27 log units) below the measured one; low and high end bracket the measured number.
By their numbers in this assay, from the lowest: compounds 3, 1 and 4 (each within the scatter of the next, the first and the last beyond it); then compound 2.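

On the aromatic carbon para to a large group, in this assay, cyano in place of chloro gives a step beyond the scatter (a 2.7-fold higher number from compound 3 to compound 4 (0.43 log units; beyond the scatter)), so a single-group exchange here can separate two compounds, which the methoxy to chloro exchange did not show. Cyano in place of methoxy stays within the scatter (a 1.5-fold higher number from compound 1 to compound 4 (0.18 log units; within the scatter)), so only the chloro and cyano compounds are separated among the three with one substituent on the ring. The 3,4-dimethoxyphenyl compound also stays apart from the cyano compound (a 3.3-fold lower number from compound 2 to compound 4 (0.52 log units; beyond the scatter)).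

No measurement at hand accounts for the gap between chloro and cyano. Open, on these data alone, is whether fluoro, trifluoromethyl or a carboxylic acid on this same carbon would lie nearer to chloro or to cyano in this assay.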